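Methylcarbamoyl for methylsulfonyl on the benzyl ring of compound 2

The compounds below may be only part of what the source reports. "The series", "measured", "known", "first", "only" and "open" are said of these compounds alone.

Of the compounds shown here, three have been measured in a functional assay on HEK293 cells for agonist activity at G-protein coupled receptor 39 (Mus musculus), read by inositol phosphate accumulation; a lower number here means that less compound is needed, a higher number that more compound is needed for the effect. Compound 1 `Cc1nc(NCc2ccc(Cl)cc2)cc(-c2ccccn2)n1` gives 17 nM, compound 3 `CNc1nc(NC2(c3ccc(Cl)cc3)CCC2)cc(-c2ccccn2)n1` gives 34 nM, and compound 2 `CNc1nc(NCc2ccc(S(C)(=O)=O)cc2)cc(-c2ccccn2)n1` gives 185 nM, the highest number of the three, with compound 3 nearest and compound 1 furthest, both beyond the scatter. Compound 4 `CNC(=O)c1ccc(CNc2cc(-c3ccccn3)nc(NC)n2)cc1` differs from compound 2 in one place: methylcarbamoyl in place of methylsulfonyl on an aromatic carbon. For the measured compounds named here, no pair of measured compounds shows how this change acts in this assay, so the expectation rests on compound 2 alone, whose 185 nM is taken as the anchor. The author expects a step from compound 2 to compound 4 of a 1.4-fold lower number from compound 2 to compound 4 (0.15 log units; within the scatter), not beyond the scatter. Compound 4 is therefore estimated at 130 nM, within a range from 40 nM to 450 nM.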

Compound 4, half-maximal effective concentration: 8 nM
The estimate for compound 4 lay 16-fold (1.21 log units) above the measured number, outside the stated range (below it).
By their numbers in this assay, from the lowest: compound 4; then compounds 1 and 3 (each within the scatter of the next); then compound 2.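

In this assay, methylcarbamoyl in place of methylsulfonyl on this aromatic carbon gives a 23-fold lower number from compound 2 to compound 4 (1.36 log units; beyond the scatter), which shows that the number depends strongly on which of these two groups the position carries. The step arises between groups of equal heavy-atom count and no net charge, which differ in that methylcarbamoyl brings a hydrogen-bond donor and a nitrogen. Nothing measured here ties the step to any of these differences. Going by these compounds, what a dimethylcarbamoyl group or a carboxylic acid would give at this position remains open. So does whether methylcarbamoyl would act alike on the other compounds.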